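From 2-Fluorophenyl to Benzyl on the Shared Core

The compounds below may be only part of what the source reports. "The series", "measured", "known", "first", "only" and "open" are said of these compounds alone.

Among the measured compounds shown here, compound 2 `CCCCCCOc1ccc(-n2cnnc2-c2ccccc2F)cc1` was tested in a functional assay on the whole organism (strain C57B/6) with Mus musculus as the target, in the maximal electroshock model; a lower number here means that less compound is needed, a higher number that more compound is needed for the effect; compound 2 gives 20.2 mg/kg, the highest of the two numbers known so far. Its nearest neighbour is compound 1 `CCCCCCOc1ccc(-n2cnnc2)cc1`, which in this assay gives 9.8 mg/kg. For the measured compounds named here, the one measured step between them, a 2.1-fold higher number from compound 1 to compound 2 (0.31 log units; beyond the scatter), came with 2-fluorophenyl in place of hydrogen on an aromatic carbon. Compound 3 `CCCCCCOc1ccc(-n2cnnc2Cc2ccccc2)cc1` is not yet measured; it differs from compound 2 by benzyl in place of 2-fluorophenyl on an aromatic carbon. Going by the values given here, no measured step exchanges one such group for another; the only step known, a 2.1-fold higher number from compound 1 to compound 2 (0.31 log units; beyond the scatter), adds a group where before there was hydrogen, and even that change was modest. On that basis no step beyond the scatter is expected, and compound 3 is estimated at 18 mg/kg, within a range of 8 mg/kg to 40 mg/kg. That estimate corresponds to an expected step of a 1.1-fold lower number from compound 2 to compound 3 (0.05 log units; within the scatter).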

Compound 3, dose for half-maximal effect: 19 mg/kg
For compound 3 the middle estimate is 1.1-fold (0.02 log units) below the measured one, within the range that was stated.
By their numbers in this assay, from the lowest: compounds 1, 3 and 2 (each within the scatter of the next, the first and the last beyond it).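

Among the compounds shown here, at the aromatic carbon between two ring nitrogen atoms, this is the first exchange of one large group for another, and in this assay it gives a 1.1-fold lower number from compound 2 to compound 3 (0.03 log units; within the scatter) so benzyl, made of carbon only, and 2-fluorophenyl, which carries fluorine, cannot be told apart here. Benzyl in place of hydrogen gives a 1.9-fold higher number from compound 1 to compound 3 (0.29 log units; within the scatter) whereas 2-fluorophenyl in place of hydrogen gave a 2.1-fold higher number from compound 1 to compound 2 (0.31 log units; beyond the scatter) and these two steps fall on opposite sides of the scatter. Both lie close to its edge, so this split is thin support for any real difference between the two groups.

Nothing measured here offers a reason for these results. As far as these compounds go, whether an amine, a carboxylic acid or a phenyl ring on a longer chain at this carbon would also stay this close to compound 3 remains open.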